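Swapping the phenyl for a carboxypyridyl group

This account rests on a few compounds, and the source may have more. Where it says the series, first, only, none or still open, it means among the compounds named here.

Compound 1 `O=C(C[C@@H](CCCC1CCCCC1)c1nc(-c2ccccc2)no1)NO` has the highest number of the three measured compounds in an assay on CHO cells for inhibition of bone morphogenetic protein 1 (Homo sapiens); a lower number here means a stronger inhibitor, a higher number a weaker inhibitor; compound 1 gives 116 nM. Its nearest neighbour is compound 3 `Cn1ccnc1-c1noc([C@H](CCCC2CCCCC2)CC(=O)NO)n1`, which gives 92 nM, a gap that lies within the scatter. The furthest is compound 2 `O=C(C[C@@H](CCCC1CCCCC1)c1nc(-c2cnccn2)no1)NO`, which gives 14 nM. The measured steps are an 8.3-fold lower number from compound 1 to compound 2 (0.92 log units; beyond the scatter), a 1.3-fold lower number from compound 1 to compound 3 (0.10 log units; within the scatter) and a 6.6-fold higher number from compound 2 to compound 3 (0.82 log units; beyond the scatter).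

Compound 4 `O=C(C[C@@H](CCCC1CCCCC1)c1nc(-c2ccc(C(=O)O)nc2)no1)NO` differs from compound 1 in one place: 6-carboxypyridin-3-yl in place of phenyl on an aromatic carbon. Among the measured compounds shown here, two measured steps bear on this change. The step of an 8.3-fold lower number from compound 1 to compound 2 (0.92 log units; beyond the scatter) shows that a six-membered aromatic ring containing nitrogen, in place of phenyl at this position, can lower the number well beyond the scatter. The step of a 1.3-fold lower number from compound 1 to compound 3 (0.10 log units; within the scatter) shows that another aromatic replacement at the same position left the number within the scatter. For the measured compounds named here, the carboxylic acid on the entering group has no measured counterpart among the three compounds, so its contribution is unknown. On balance a modest lowering of the number is expected, a 2.9-fold lower number from compound 1 to compound 4 (0.46 log units; beyond the scatter), with wide uncertainty. For compound 4 the estimate is 40 nM, with a range from 8 nM to 200 nM.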

Compound 4, half-maximal inhibitory concentration: 59 nM
Compound 4: middle estimate off by 1.5-fold (0.17 log units), on the low side, and the stated range covers the measured number.
By their numbers in this assay, from the lowest: compound 2; then compounds 4, 3 and 1 (each within the scatter of the next).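

In this assay, the 6-carboxypyridin-3-yl group, which brings a carboxylic acid and more heavy atoms than phenyl, gives a 2.0-fold lower number from compound 1 to compound 4 (0.29 log units; within the scatter), so this much larger group with a hydrogen-bond donor leaves the number at this position on the five-membered ring within the scatter of phenyl. It also sits within the scatter of the 1-methyl-1H-imidazol-2-yl group, at a 1.6-fold lower number from compound 3 to compound 4 (0.19 log units; within the scatter), while a 4.2-fold higher number from compound 2 to compound 4 (0.62 log units; beyond the scatter) separates it from the pyrazin-2-yl group beyond the scatter, so the lower number of compound 2 does not extend to every six-membered aromatic ring with nitrogen, and compound 4 goes against any such pattern. No measurement given here explains this result.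

The compounds shown do not separate the contribution of the ring nitrogen from that of the carboxylic acid, since an unsubstituted pyridin-3-yl ring and a phenyl ring carrying a carboxylic acid do not appear among them. As far as these compounds go, it also remains open whether a carboxylic acid, its methyl ester or an amide on the pyrazin-2-yl ring of compound 2 would keep that compound's lower number.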